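Removing a methylsulfonyl from an aminopyridine amide series

The compounds below may be only part of what the source reports. "The series", "measured", "known", "first", "only" and "open" are said of these compounds alone.

Measured compounds:
Compound 1, `CS(=O)(=O)Nc1ccc(-c2cccc(C(=O)N[C@H]3CN[C@@H](C(=O)Nc4ccc(Cl)c(C(F)(F)F)c4)C3)c2)cn1`, 24600 nM
Compound 2, `CS(=O)(=O)Nc1ccc(-c2ccc(C(=O)N[C@H]3CN[C@@H](C(=O)Nc4ccc(Cl)c(C(F)(F)F)c4)C3)cc2)cn1`, 45000 nM
Compound 3, `Nc1ccc(-c2ccc(C(=O)N[C@H]3CN[C@@H](C(=O)Nc4ccc(Cl)c(C(F)(F)F)c4)C3)cc2)cn1`, 9130 nM

All three compounds were tested in a functional assay on K562 cells (Homo sapiens) for inhibition, read by MTT assay, with a stated time of 48 h; a higher number here means a weaker inhibitor, a lower number a stronger inhibitor. Compound 1 and compound 2 are built from the same atoms joined differently; the difference between their two cores is not broken down here. Their values lie within the usual scatter of each other, so no order between compound 1 and compound 2 can be read from them. Compound 3 differs from compound 2 by hydrogen in place of methylsulfonyl on a nitrogen on an aromatic ring, and this change gave a 4.9-fold lower number from compound 2 to compound 3 (0.69 log units; beyond the scatter).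

The unmeasured compound 4, `Nc1ccc(-c2cccc(C(=O)N[C@H]3CN[C@@H](C(=O)Nc4ccc(Cl)c(C(F)(F)F)c4)C3)c2)cn1`, stands to compound 1 as compound 3 stands to compound 2: it differs from compound 1 by hydrogen in place of methylsulfonyl on a nitrogen on an aromatic ring. The place of the change is described in the same words for both pairs, so it is the same change, made once on each core. Among the compounds with values here, the expectation for compound 4 rests on the single earlier instance, the step of a 4.9-fold lower number from compound 2 to compound 3 (0.69 log units; beyond the scatter), carried over to compound 1 with its value 24600 nM. Because of a 4.9-fold lower number from compound 2 to compound 3 (0.69 log units; beyond the scatter) a step of similar size is expected on the other core. The expected step is a 4.9-fold lower number from compound 1 to compound 4 (0.69 log units; beyond the scatter). Compound 4 is therefore estimated at 5000 nM in this assay, with a range from 2000 nM to 15000 nM that allows for the change being seen only once so far.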

Compound 4, half-maximal inhibitory concentration: 20000 nM
The estimate for compound 4 lay 4.0-fold (0.60 log units) below the measured number, outside the stated range (above it).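

In this assay, the change from methanesulfonamido to amino on the core of compound 1 gave a 1.2-fold lower number from compound 1 to compound 4 (0.09 log units; within the scatter), a step that lies within the scatter and so shows no measurable gain or loss. The same change had given a step beyond the scatter on the other core, so its size did not carry over from one core to the other in this series: the same change on two cores in this assay, a 4.9-fold lower number (0.69 log units; beyond the scatter) from compound 2 to compound 3 and a 1.2-fold lower number (0.09 log units; within the scatter) from compound 1 to compound 4, 4.0-fold (0.60 log units) apart, beyond the scatter of two such steps

Within the data shown here, this shows that a step measured on one of these cores cannot simply be transferred to the other, but it rests on only two pairs and does not show which difference between the cores goes with the difference in the steps, nor what the change would do on any further core.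

The compounds shown carry only hydrogen or methylsulfonyl on that nitrogen, so it remains open whether an acetyl or a methyl group there would give steps that also differ between the two cores. All four compounds also keep the same chlorine and trifluoromethyl groups, which leaves open how the two cores would compare with a nitrile in place of that chlorine.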